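Trifluoromethyl to cyano in a weakly antiproliferative series

This account rests on a few compounds, and the source may have more. Where it says the series, first, only, none or still open, it means among the compounds named here.

Three compounds measured in a functional assay on DU-145 cells (Homo sapiens) for antiproliferative activity, read by propidium iodide staining, with a stated time of 96 h (on this read-out lower numbers stand for stronger inhibition and higher numbers for weaker inhibition), give these values:

- Compound 1 `CC(O)(CSc1ccc(OC(F)(F)F)cc1)C(=O)Nc1ccc(S(F)(F)(F)(F)F)cc1` gives 12500 nM
- Compound 2 `CC(O)(COc1ccc(OC(F)(F)F)cc1)C(=O)Nc1ccc(S(F)(F)(F)(F)F)cc1` gives 24800 nM
- Compound 3 `CC(O)(COc1ccc(C(F)(F)F)cc1)C(=O)Nc1cccc(S(F)(F)(F)(F)F)c1` gives 13600 nM

The account turns to compound 3 (13600 nM). Among these three numbers it is the second highest, but that placing carries little weight. Its value lies within the usual scatter of compound 1 (12500 nM) and also within the usual scatter of compound 2 (24800 nM), so it cannot be separated from either.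

The next compound to be tested is compound 4 `CC(O)(COc1ccc(C#N)cc1)C(=O)Nc1cccc(S(F)(F)(F)(F)F)c1`, which differs from compound 3 in one place. It has cyano in place of trifluoromethyl on an aromatic carbon, para to a large group cyano in place of trifluoromethyl on an aromatic carbon and the rest of the structure is unchanged.

For the measured compounds named here, the measurements so far offer no direct step for this change, so any expectation remains loose. In this assay no change beyond the scatter is expected, with only a slight lean towards a higher number, and the estimated step is small (a 1.4-fold higher number from compound 3 to compound 4 (0.15 log units; within the scatter)). The estimate for compound 4 is an expected value of 19000 nM (expected range 8000 nM to 45000 nM).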

Compound 4, half-maximal inhibitory concentration: 42600 nM
For compound 4 the middle estimate is 2.2-fold (0.35 log units) below the measured one, within the range that was stated.
By their numbers in this assay, from the lowest: compounds 1, 3, 2 and 4 (each within the scatter of the next, the first and the last beyond it).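

In this assay, cyano in place of trifluoromethyl on an aromatic carbon, para to a large group, gives a 3.1-fold higher number from compound 3 to compound 4 (0.50 log units; beyond the scatter) and provides the first single-place comparison among the compounds shown. The step is modest but lies beyond the scatter, so this position is not indifferent to the group it carries, and within this one pair the change goes towards weaker inhibition. The compounds come with no data that would tie this loss to any property of either group.

Going by these compounds, a single pair cannot show whether the trend extends to other groups at this place, so it remains open whether a chlorine atom, a methoxy group, an amine or a carboxylic acid would stay close to compound 3 or fall towards compound 4. It also remains open whether the same swap from trifluoromethyl to cyano would give a step of similar size on a different background, since the other compounds shown carry trifluoromethoxy at the corresponding place and offer no second pair for this change.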